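A few compounds are considered here, and "the series" means these few. Any claim that something is new, unique, unknown or untested is made for them only; others in the source may bear on it.

Compound 1 `Nc1cc2ccccc2cc1NC(=O)c1ccc(CNc2nccc(-c3cccnc3)n2)cc1` was tested in an assay for inhibition of histone deacetylase 8 (Homo sapiens), read by fluorescence, with stated times of 15 min and 60 min; on this read-out higher numbers stand for weaker inhibition and lower numbers for stronger inhibition. In this assay compound 1 gives > 20000 nM, which is a limit of the assay rather than a measured number (the limit of > 20000 nM in this assay, at which 1 of the 3 values shown sits). Two other compounds built on the same shared core, but differing from compound 1 in other parts of the structure, were measured as well: compound 2 `Nc1ccccc1NC(=O)c1ccc(CNC2=N[C@H](Cc3ccccc3)CS2)cc1` gives 12700 nM in this assay, and compound 3 `Nc1ccccc1NC(=O)c1ccc(CNC2=NC[C@H](c3ccccc3)S2)cc1` gives 2300 nM in this assay. Compound 4 `Nc1cc(C(=O)O)ccc1NC(=O)c1ccc(CNc2nccc(-c3cccnc3)n2)cc1` has not yet been measured; it differs from compound 1 by a group of 10 heavy atoms (7 carbon, 1 nitrogen, 2 oxygen; one six-membered aromatic ring of carbon only) in place of a group of 11 heavy atoms (10 carbon, 1 nitrogen; 2 six-membered aromatic rings of carbon only), on an amide-type nitrogen. Among the measured compounds shown here, no measured pair differs in just this way, so the size of the step is open. The step expected is an at least 1.3-fold lower number from compound 1 to compound 4 (0.12 log units; that floor lies within the scatter), within the scatter. Compound 4 is expected to give 15000 nM in this assay, in a range from 5000 nM to 40000 nM.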

Compound 4, half-maximal inhibitory concentration: > 20000 nM
Compound 4: only a limit was reported; the forecaster's own chance of this, stated with the estimate: 50%; middle value at least 1.3-fold (0.12 log units) away from the limit.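

Among the compounds shown here, compound 1 and compound 4 both stop at a limit of the assay, so no step between them can be read: the limit of > 20000 nM in this assay, at which 2 of the 4 values shown sit. As far as these compounds go, how strongly either compound inhibits, and whether the 2-amino-4-carboxyphenyl group changes that, stays open.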